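The source may report more compounds than this note shows. Statements on the series, on what has been measured and on what is new or still open speak of the compounds shown alone.

Measured in an ADME assay on KB cells (Homo sapiens) for cytotoxicity, with a stated time of 48 h (on this read-out higher numbers stand for weaker inhibition and lower numbers for stronger inhibition), each value a limit and not a number:
- compound 1 `CC1=CCC[C@](C)(CC/C(C)=C/CC2=C(O)C(=O)C=C(N[C@@H](C(=O)O)C(C)C)C2=O)[C@@H]1C`: > 10 ug/mL
- compound 2 `CC1=CCC[C@](C)(CC/C(C)=C/CC2=C(O)C(=O)C=C(N[C@H](CO)C(=O)O)C2=O)[C@@H]1C`: > 10 ug/mL
- compound 3 `COC1=CC(=O)C(O)=C(C/C=C(\C)CC[C@@]2(C)CCC=C(C)[C@H]2C)C1=O`: > 10 ug/mL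

Compound 3 gives only a limit, > 10 ug/mL. The whole set offers just (the limit of > 10 ug/mL in this assay, at which 3 of the 3 values shown sit).

Going to compound 4 `CC1=CCC[C@](C)(CC/C(C)=C/CC2=C(O)C(=O)C=C(N[C@H](C(=O)O)[C@H](C)O)C2=O)[C@@H]1C` puts (1-carboxy-2-hydroxypropyl)amino in place of methoxy on a double-bonded ring carbon.

Compound 1 and compound 2 carry related amino groups at that place, so two measured changes bear on this one: a step that the two limits leave unreadable from compound 1 to compound 3, and a step that the two limits leave unreadable from compound 2 to compound 3. Neither gives a size or direction, so no change beyond the scatter is expected in this assay, and another limit is likely. The estimated change is a step that the limit leaves unreadable from compound 3 to compound 4. For compound 4 the expected value is 15 ug/mL, with an expected range of 8 ug/mL to 40 ug/mL.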

Compound 4, half-maximal inhibitory concentration: > 10 ug/mL
Compound 4 ended at the assay's limit; the forecaster's own chance of this, stated with the estimate: 85%; the middle value lies beyond the limit too.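

Compound 4, like compound 1, compound 2 and compound 3, gives only a limit, so no step among them can be read: the limit of > 10 ug/mL in this assay, at which 4 of the 4 values shown sit.

What the compounds shown leave open is whether any of them, at any strength, inhibits these cells in this assay.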